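Replacing the piperidin-1-yl group of compound 3

A few compounds are considered here, and "the series" means these few. Any claim that something is new, unique, unknown or untested is made for them only; others in the source may bear on it.

In an ADME assay (liver) for metabolic stability, with Liver microsome (Homo sapiens) as the target, using microsomes (a higher number here means that the compound lasts longer, a lower number that the compound disappears faster), compound 3 `CCc1nc2cc(Cl)ccn2c1C(=O)NCc1ccc(N2CCCCC2)cc1` gives 0.22 h and compound 1 `CCCc1nc2ccccn2c1C(=O)NCc1ccc(-c2ccccc2)cc1` gives 0.373 h, two values within the usual scatter of each other. Compound 2 `CCc1nc2ccc(Cl)cn2c1C(=O)NCc1ccc(-c2ccc(C#N)cc2)cc1` reaches > 2 h, which is a limit of the measurement and not a number. Compound 3 therefore stands level with compound 1, at the short end of the half-lives seen so far. Compound 4 `CCc1nc2cc(Cl)ccn2c1C(=O)NCc1ccc(-n2cc3c(c2)CCCC3)cc1` differs from compound 3 by a group of 9 heavy atoms (8 carbon, 1 nitrogen; one five-membered aromatic ring with 1 hetero atom, one six-membered non-aromatic ring of carbon only) in place of a group of 6 heavy atoms (5 carbon, 1 nitrogen; one six-membered non-aromatic ring with 1 hetero atom), on an aromatic carbon. Within the data shown here, no measured pair shows this kind of change, so the expected step in this assay is small, a 1.4-fold higher number from compound 3 to compound 4 (0.13 log units; within the scatter), a slight rise that stays within the scatter. Compound 4 is estimated at 0.3 h, with an expected range from 0.12 h to 0.8 h.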

Compound 4, half-life: 0.455 h
For compound 4 the middle estimate is 1.5-fold (0.18 log units) below the measured one, within the range that was stated.
By their numbers in this assay, from the lowest: compounds 3, 1 and 4 (each within the scatter of the next, the first and the last beyond it). At a limit, above all of these: compound 2.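

Among these compounds, compounds 3 and 4 give the first readable step at this place, an aromatic carbon para to a large group: in this assay, replacing piperidin-1-yl with the larger two-ring group gives a 2.1-fold higher number from compound 3 to compound 4 (0.32 log units; beyond the scatter), a modest change. The half-life therefore responds to the group carried here, but no measurement shown explains why.

As far as these compounds go, whether the rise depends on the five-membered aromatic ring, the added carbon ring or both remains open. So does the outcome with another group here, such as morpholin-4-yl or dimethylamino.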